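Replacing morpholine by 3-aminopiperidine in an amide series

The compounds below may be only part of what the source reports. "The series", "measured", "known", "first", "only" and "open" are said of these compounds alone.

The measured compounds are:
compound 1, `NC1CCN(C(=O)c2ccc(-c3ccc4ncc(-c5ccc6cnccc6c5)n4c3)cc2)CC1`, 16.8 nM;
compound 2, `N[C@H]1CCCN(C(=O)c2ccc(-c3ccc4ncc(-c5ccc6cnccc6c5)n4c3)cc2)C1`, 2.5 nM;
compound 3, `O=C(c1ccc(-c2ccc3ncc(-c4ccc5cnccc5c4)n3c2)cc1)N1CCOCC1`, 7 nM.

All three were tested in an assay on Sf21 cells for inhibition of MAP kinase-interacting serine/threonine-protein kinase 1 (Homo sapiens), read by luminescence and ADP-Glo, with stated times of 10 min and 40 min; on this read-out higher numbers stand for weaker inhibition and lower numbers for stronger inhibition. Among the three numbers, compound 3 holds the second highest: its nearest neighbour is compound 1, separated by a 2.4-fold lower number from compound 1 to compound 3 (0.38 log units; beyond the scatter), and its furthest is compound 2, separated by a 2.8-fold higher number from compound 2 to compound 3 (0.45 log units; beyond the scatter).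

Compound 4, `N[C@@H]1CCCN(C(=O)c2ccc(-c3ccc4ncc(-c5ccc6cnccc6c5)n4c3)cc2)C1`, has not been measured. It differs from compound 3 in one place: 3-aminopiperidin-1-yl in place of morpholin-4-yl on a carbonyl carbon. The group that enters is the same as that of compound 2, drawn with the opposite configuration at its stereocentre.

Within the data shown here, two measured steps bear on the change. Read in reverse, a 2.4-fold lower number from compound 1 to compound 3 (0.38 log units; beyond the scatter) and a 2.8-fold higher number from compound 2 to compound 3 (0.45 log units; beyond the scatter) both point to a lower number when an amine-bearing ring takes the place of morpholin-4-yl. Among the measured compounds shown here, since the configuration of compound 4 has no measured counterpart, a smaller shift than that of compound 2 is expected, roughly a 1.4-fold lower number from compound 3 to compound 4 (0.15 log units; within the scatter). Compound 4 is therefore estimated at 5 nM, with a likely range from 1.5 nM to 20 nM.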

Compound 4, half-maximal inhibitory concentration: 7.7 nM
Compound 4: middle estimate off by 1.5-fold (0.19 log units), on the low side; measured number inside the range.
By their numbers in this assay, from the lowest: compound 2; then compounds 3 and 4 (each within the scatter of the next); then compound 1.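

In this assay, 3-aminopiperidin-1-yl in place of morpholin-4-yl on a carbonyl carbon gives a 1.1-fold higher number from compound 3 to compound 4 (0.04 log units; within the scatter), so in this configuration the amine-bearing ring offers no measurable advantage over morpholin-4-yl. The advantage seen with compound 2 is tied to the stereocentre, as a 3.1-fold higher number from compound 2 to compound 4 (0.49 log units; beyond the scatter) shows, and the configuration can be singled out because of one fact: the fact that compounds 2 and 4 differ only in the configuration as drawn. Even so, the 3-aminopiperidin-1-yl group of compound 4 retains an edge over 4-aminopiperidin-1-yl, with a 2.2-fold lower number from compound 1 to compound 4 (0.34 log units; beyond the scatter).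

Going by these compounds, whether the same preference between configurations would hold for a 3-aminopyrrolidin-1-yl ring, or for a dimethylamino group in place of the primary amine on the piperidine, remains open. The compounds shown also give no explanation of why the two configurations differ.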